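Alkyl chain length on a selenium-bearing core: cytotoxicity

The source may hold more compounds than are shown below. What is called first, only, known or untested is meant among the compounds shown, and "the series" means these compounds.

Measured compounds:
- compound 1, `COc1ccc(CNc2nc([Se]C)nc3ccccc23)cc1`: > 100000 nM in a functional assay on MCF7 cells (Homo sapiens) for cytotoxicity, read by MTT assay, with a stated time of 72 h; on this read-out higher numbers stand for lower toxicity in this test and lower numbers for higher toxicity in this test (a limit of the assay)
- compound 2, `C[Se]c1nc(N)c2ccccc2n1`: > 100000 nM in this assay (a limit of the assay)
- compound 3, `C[Se]c1nc([Se]C)c2ccccc2n1`: > 100000 nM in this assay (a limit of the assay)

None of the three measured compounds reached a readable number in this assay; each sits at the limit of > 100000 nM in this assay, at which 3 of the 3 values shown sit. Compound 2 therefore stands only at a limit, not at a value. Among the compounds with values here, the one measured step between neighbours, a step that the two limits leave unreadable from compound 2 to compound 3, cannot be sized, since both ends are limits.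

Compound 4, `CCCCC[Se]c1nc(N)c2ccccc2n1`, differs from compound 2 by butyl in place of hydrogen on a saturated chain carbon bound to a selenium atom. Within the data shown here, no measured step touches this kind of change, so the only guide is that compound 1, compound 2 and compound 3, which differ among themselves in other places, all sit at the limit of > 100000 nM in this assay, at which 3 of the 3 values shown sit. On that basis compound 4 is expected to show no step beyond the scatter in this assay, the estimated step being a number no higher from compound 2 to compound 4 (the limit leaves the size open). The estimate for compound 4 in this assay is 100000 nM, with a range from 30000 nM to 300000 nM, most likely again reported only as a limit.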

Compound 4, concentration lethal to 50% of the cells: 90400 nM
Compound 4: middle estimate off by 1.1-fold (0.04 log units), on the high side, and the stated range covers the measured number.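

Within the data shown here, this change is the first to give a readable number: with pentyl in place of methyl, compound 4 gives 90400 nM in this assay. The step reads an at least 1.1-fold lower number from compound 2 to compound 4 (0.04 log units; that floor lies within the scatter), and that figure is only a floor, so the data allow either a very small gap or a much larger one. The true size stays unknown because compound 2 stands at a limit rather than a value, as do the other earlier compounds: the limit of > 100000 nM in this assay, at which 3 of the 4 values shown sit.

From the compounds shown here alone, whether a propyl chain or a longer chain such as octyl, in place of pentyl, would give a number further from that limit remains open. Going by these compounds, it is also open whether pentyl would have a similar outcome on compound 1 or compound 3, which carry other groups on the shared core.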